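Shrinking a two-ring group to a dimethylpyrazole on the amide arm

This account rests on a few compounds, and the source may have more. Where it says the series, first, only, none or still open, it means among the compounds named here.

Of the compounds shown here, three sharing one core have been measured in a functional assay on CHO-K1 cells for antagonist activity at C-X-C chemokine receptor type 3 (Homo sapiens), read by FLIPR, with a stated time of 10 min; on this read-out higher numbers stand for weaker inhibition and lower numbers for stronger inhibition. Compound 1 `CCOc1ncc(-c2nc(C(F)(F)F)sc2N2CCN(C(=O)Cn3cnc4ccccc43)[C@H](C)C2)cn1` gives 2 nM; compound 2 `CCOc1ncc(-c2nc(C(F)(F)F)sc2N2CCN(C(=O)Cn3ccc4cccnc43)[C@H](C)C2)cn1` gives 3.8 nM; compound 3 `CCOc1ncc(-c2nc(C(F)(F)F)sc2N2CCN(C(=O)Cn3c(=O)oc4ccccc43)[C@H](C)C2)cn1` gives 3.3 nM. Compound 3 thus holds the second highest of the three numbers, with compound 2 nearest and compound 1 furthest, and every gap among them falls within the scatter, so none of the three can be called stronger or weaker than another.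

Compound 4 `CCOc1ncc(-c2nc(C(F)(F)F)sc2N2CCN(C(=O)Cn3nc(C)cc3C)[C@H](C)C2)cn1` arises from compound 3 by the change (a group of 7 heavy atoms (5 carbon, 2 nitrogen; one five-membered aromatic ring with 2 hetero atoms) in place of a group of 10 heavy atoms (7 carbon, 1 nitrogen, 2 oxygen; one five-membered aromatic ring with 2 hetero atoms, one six-membered aromatic ring of carbon only), on a saturated chain carbon bound to a carbonyl carbon). The steps measured so far, a 1.9-fold higher number from compound 1 to compound 2 (0.28 log units; within the scatter), a 1.7-fold higher number from compound 1 to compound 3 (0.22 log units; within the scatter) and a 1.2-fold lower number from compound 2 to compound 3 (0.06 log units; within the scatter), each exchanged one two-ring group for another two-ring group at this same position and all stayed within the scatter. Among the compounds with values here, no measured step removes a ring at this position, so the present change reaches beyond what the data test. On that basis a modest move toward a higher number in this assay is expected, a 2.4-fold higher number from compound 3 to compound 4 (0.38 log units; beyond the scatter), with wide uncertainty. Compound 4 is estimated at 8 nM, within a range of 2.5 nM to 30 nM.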

Compound 4, half-maximal inhibitory concentration: 2.3 nM
Beside the measured number, compound 4's estimate is 3.5-fold (0.54 log units) above it, outside the stated range (below it).
By their numbers in this assay, from the lowest: compounds 1, 4, 3 and 2 (each within the scatter of the next).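

In this assay, within the data shown here, putting the single-ring 3,5-dimethyl-1H-pyrazol-1-yl on the saturated chain carbon bound to a carbonyl carbon gives a 1.4-fold lower number from compound 3 to compound 4 (0.16 log units; within the scatter) and a 1.7-fold lower number from compound 2 to compound 4 (0.22 log units; within the scatter) and a 1.2-fold higher number from compound 1 to compound 4 (0.06 log units; within the scatter) with no step leaving the scatter. The earlier compounds shown here only exchanged one two-ring group for another, whereas this result shows that a group of 7 heavy atoms with one ring can stand at this place without a measurable change in the read-out. Nothing available here explains why the number holds when the group shrinks.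

From the compounds shown here alone, it remains open whether a plain 1H-pyrazol-1-yl without its two methyl groups would keep the number in this range. Also open, going by these compounds, is what a much smaller or differently built group, such as a dimethylamino group or a carboxylic acid, would do at this place.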